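All three aryltriazole analogues sit at the assay limit

The source may report more compounds than this note shows. Statements on the series, on what has been measured and on what is new or still open speak of the compounds shown alone.

Measured compounds:
- compound 1 `N#CC1=C(N)Oc2c(N)cc3nc4ccccc4nc3c2C12C(=O)N(Cc1cnnn1-c1cccc(Br)c1)c1ccccc12`: in a functional assay on MCF7 cells (Homo sapiens) for antiproliferative activity, read by MTT assay, with a stated time of 48 h (a higher number here means a weaker inhibitor, a lower number a stronger inhibitor), compound 1 gives > 50000 nM, a limit of the assay.
- compound 2 `CCc1cccc(C)c1-n1nncc1CN1C(=O)C2(C(C#N)=C(N)Oc3c(N)cc4nc5ccccc5nc4c32)c2ccccc21`: compound 2 gives > 50000 nM, a limit of the assay.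
- compound 3 `Cc1ccc(C)c(-n2nncc2CN2C(=O)C3(C(C#N)=C(N)Oc4c(N)cc5nc6ccccc6nc5c43)c3ccccc32)c1`: compound 3 gives > 50000 nM, a limit of the assay.

Compound 3 stands where the other two stand: at the assay limit, not at a number. The steps a step that the two limits leave unreadable from compound 1 to compound 2, a step that the two limits leave unreadable from compound 1 to compound 3 and a step that the two limits leave unreadable from compound 2 to compound 3 are unreadable, each pair being two limits; none of the three values allows any ordering, as the limit of > 50000 nM in this assay, at which 3 of the 3 values shown sit, records.

Compound 4 `Cc1cc(C)c(-n2nncc2CN2C(=O)C3(C(C#N)=C(N)Oc4c(N)cc5nc6ccccc6nc5c43)c3ccccc32)c(C)c1` differs from compound 3 only at the aryl group on the triazole nitrogen: 2,4,6-trimethylphenyl in place of 2,5-dimethylphenyl on an aromatic nitrogen. Every measured step that bears on this change, the exchange of one aryl group for another on that nitrogen, gives no readable size. Nothing measured here shows any aryl group on this nitrogen bringing a value within the range of the assay, and a trimethyl variant is expected to behave like the dimethyl variant in compound 3.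

The expectation for compound 4 is therefore that this assay again reports a limit, with a step that the limit leaves unreadable from compound 3 to compound 4 that cannot be told from the scatter. The estimate for compound 4 is 60000 nM, with a range from 30000 nM to 150000 nM, and the most likely outcome being a limit rather than a number.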

Compound 4, half-maximal inhibitory concentration: > 50000 nM
Compound 4: no number, only a limit; the forecaster's own chance of this, stated with the estimate: 85%; the middle value lies beyond the limit too.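

In this assay compound 4 gives > 50000 nM, a limit of the assay. Within the data shown here, no step from compound 1, compound 2 or compound 3 to compound 4 can be read, each pair being two limits: the limit of > 50000 nM in this assay, at which 4 of the 4 values shown sit.

The compounds shown leave open whether any aryl group on this aromatic nitrogen brings a value within the range of this assay, and how these four compounds rank.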